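A few compounds are considered here, and "the series" means these few. Any claim that something is new, unique, unknown or untested is made for them only; others in the source may bear on it.

Working notes on the series in a functional assay on DU-145 cells (Homo sapiens) for cytotoxicity, read by CCK-8 assay, with a stated time of 4 days; on this read-out higher numbers stand for weaker inhibition and lower numbers for stronger inhibition. Compound 1 `Oc1ccc(-c2cc(-c3ccc(O)cc3)nc(-c3ccc(O)cc3)c2)cc1` gives 3160 nM and compound 2 `Oc1ccc(-c2cc(-c3ccccc3O)cc(-c3ccccc3O)n2)cc1` gives 360 nM. Compound 3 `Oc1ccc(-c2cc(-c3cccc(O)c3)nc(-c3ccccc3O)c2)cc1` gives 3420 nM, the highest of the three numbers; its gap to compound 1 is within the scatter, while compound 2 sits well beyond it with the lower number. Compound 4 `Oc1ccc(-c2cc(-c3cccc(O)c3)nc(-c3cccc(O)c3)c2)cc1` has the same atoms as compound 3, joined differently: 3-hydroxyphenyl in place of 2-hydroxyphenyl on an aromatic carbon. Among the compounds with values here, no measured step isolates this change, so direction rests on what the three compounds show. Compound 2, with two 2-hydroxyphenyl groups, carries the low number, and compound 3 keeps only one; removing it is expected to leave the number high or push it somewhat higher, with a step from compound 3 to compound 4 of a 1.3-fold higher number from compound 3 to compound 4 (0.12 log units; within the scatter) expected. For compound 4 the estimate is 4500 nM, within 2000 nM to 12000 nM.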

Compound 4, half-maximal inhibitory concentration: 1760 nM
For compound 4 the middle estimate is 2.6-fold (0.41 log units) above the measured one; the whole stated range lies above it.
By their numbers in this assay, from the lowest: compound 2; then compounds 4, 1 and 3 (each within the scatter of the next).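

Within the data shown here, at the aromatic carbon next to the ring nitrogen, 3-hydroxyphenyl in place of 2-hydroxyphenyl gives a 1.9-fold lower number from compound 3 to compound 4 (0.29 log units; within the scatter), the first single-place step. In this assay, this exchange therefore gives no clear direction at this position. No supporting data bear on the reason for this result.

On these data alone, whether an amine or a carboxylic acid on the phenyl ring at this position would give a different number remains open. Among these compounds, also open is what underlies the 360 nM of compound 2, as no single-place step connects it to the others.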